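The source may hold more compounds than are shown below. What is called first, only, known or untested is meant among the compounds shown, and "the series" means these compounds.

Compound 1 `CCN1C(=O)CS/C1=N/Nc1nncc2ccccc12`: 54 nM
Compound 2 `Cc1cc(C)nc(NS(=O)(=O)c2ccc(Nc3nncc4ccccc34)cc2)n1`: 3.4 nM

In a functional assay on UO-31 cells (Homo sapiens) for antiproliferative activity, read by sulforhodamine B assay, with a stated time of 72 h (a higher number here means a weaker inhibitor, a lower number a stronger inhibitor), compound 2 holds the lower of the two numbers at 3.4 nM, while compound 1 gives 54 nM, a gap beyond the scatter. Compound 3 `O=S(=O)(Nc1nccs1)c1ccc(Nc2nncc3ccccc23)cc1` has not yet been measured. It differs from compound 2 in one place: 1,3-thiazol-2-yl in place of 4,6-dimethylpyrimidin-2-yl on a sulfonamide nitrogen. The change puts 1,3-thiazol-2-yl in place of 4,6-dimethylpyrimidin-2-yl on a sulfonamide nitrogen. Going by the values given here, no measured pair shows what this exchange does, so any forecast is tentative. Compound 2, at 3.4 nM, already stands low, so a somewhat higher number seems more likely than a lower one. The expected 1.8-fold higher number from compound 2 to compound 3 (0.25 log units; within the scatter) in this assay is a modest rise, which may not clear the scatter. For compound 3 the estimated value is 6 nM, with an expected range from 1.5 nM to 25 nM.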

Compound 3, half-maximal inhibitory concentration: 12 nM
Beside the measured number, compound 3's estimate is 2.0-fold (0.30 log units) below it, and the stated range covers the measured number.
By their numbers in this assay, from the lowest: compound 2; then compound 3; then compound 1.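

In this assay, the group on the sulfonamide nitrogen turns out to matter: 1,3-thiazol-2-yl in place of 4,6-dimethylpyrimidin-2-yl gives a 3.5-fold higher number from compound 2 to compound 3 (0.55 log units; beyond the scatter). The 4,6-dimethylpyrimidin-2-yl group is nonetheless not the only ring that fits this place, since compound 3, with a five-membered aromatic ring of 5 heavy atoms in place of a six-membered one of 8, still gives 12 nM. Nothing available explains why the number moved with this exchange. The compounds shown leave open whether the step follows from the change of ring itself or from the loss of the two methyl groups. They also leave open how a pyridin-2-yl, an unsubstituted pyrimidin-2-yl or a simple methyl group on the sulfonamide nitrogen would read in this assay.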